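The source may report more compounds than this note shows. Statements on the series, on what has been measured and on what is new or still open speak of the compounds shown alone.

Compound 2 `O=C1NC(=S)S/C1=C\C=C\c1ccccc1OCc1ccccc1` carries a benzyloxy group on an aromatic carbon of the core it shares with compound 1 `O=C1NC(=S)S/C1=C\C=C\c1ccccc1`. In a functional assay on DLD-1 cells (Homo sapiens), read by microscopy and crystal violet staining, with a stated time of 20 h, tested at 10 ug/mL (on this read-out higher numbers stand for more inhibition at the one concentration tested (going by the name of the read-out) and lower numbers for less inhibition), compound 1 gives 81%, and compound 2 gives 65%. Of the two numbers measured, compound 2 stands lowest, and the change a number 16 percentage points lower from compound 1 to compound 2 (beyond the scatter) lies beyond the scatter. Compound 3 `O=C1NC(=S)S/C1=C\C=C\c1ccccc1Cl` differs from compound 2 in one place: chloro in place of benzyloxy on an aromatic carbon. Within the data shown here, no measured step swaps benzyloxy for chloro, so only the modest step from compound 1 to compound 2 bears on this change. Going by these compounds, because a number 16 percentage points lower from compound 1 to compound 2 (beyond the scatter) came with the arrival of benzyloxy, its removal is expected to recover part of that loss, while chloro is untested here, so the estimate stays wide. Compound 3 is expected to give about 72%, within 55% to 90%. For compound 3 this amounts to an expected a number 7 percentage points higher from compound 2 to compound 3 (within the scatter).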

Compound 3, a percentage reported as inhibition, at one concentration (the size of the read-out at that concentration, not a potency): 80%
Estimate against measurement, compound 3: 8 percentage points below; low and high end bracket the measured number.
By their numbers in this assay, from the lowest: compound 2; then compounds 3 and 1 (each within the scatter of the next).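

In this assay, this aromatic carbon can carry a substituent without a loss of inhibition: chloro in place of hydrogen leaves the number within the scatter (a number 1 percentage points lower from compound 1 to compound 3 (within the scatter)). Chloro in place of benzyloxy raises it (a number 15 percentage points higher from compound 2 to compound 3 (beyond the scatter)), so the lower number of compound 2 goes with benzyloxy in particular, not with substitution at this carbon as such. No measurement is available that explains why these two groups differ.

Going by these compounds, whether a methoxy group, an amine or a carboxylic acid on this carbon would track chloro or benzyloxy remains open. Also open, on these data alone, is whether chloro would match hydrogen in the same way on the other carbons of the six-membered aromatic ring.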